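This account rests on a few compounds, and the source may have more. Where it says the series, first, only, none or still open, it means among the compounds named here.

Going by the values given here, in an ADME assay on L6 cells (Rattus norvegicus) for cytotoxicity, read by resazurin assay, with a stated time of 72 h (on this read-out lower numbers stand for stronger inhibition and higher numbers for weaker inhibition), compound 1 `OC(c1ccc(Cl)cc1)(c1cccnc1)c1ccccc1Cl` gives 61300 nM, the only actual number in this small set. Compound 2 `OC(c1ccc(Cl)cc1)(c1ncccn1)c1ccccc1Cl` reads > 100000 nM, which is a limit. Compound 3 `OC(c1ccc(Cl)cc1)(c1ccncn1)c1ccccc1Cl` reads > 100000 nM, also a limit. Compound 4 `NC(c1ccc(Cl)cc1)(c1cccnc1)c1ccccc1Cl` has amino in place of hydroxy on a saturated chain carbon bound to three aromatic carbons. The measured steps bear on this only indirectly, since they leave the hydroxy untouched. Pyrimidin-2-yl in place of pyridin-3-yl gives an at least 1.6-fold higher number from compound 1 to compound 2 (0.21 log units; that floor lies within the scatter), and pyrimidin-4-yl gives an at least 1.6-fold higher number from compound 1 to compound 3 (0.21 log units; that floor lies within the scatter). Both are floors set by the limit of > 100000 nM in this assay, at which 2 of the 3 values shown sit. No change beyond the scatter is therefore expected in this assay, and the expected step is a 1.4-fold lower number from compound 1 to compound 4 (0.13 log units; within the scatter). For compound 4 the estimated value is 45000 nM, with an expected range of 15000 nM to 100000 nM.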

Compound 4, half-maximal inhibitory concentration: 76000 nM
For compound 4 the middle estimate is 1.7-fold (0.23 log units) below the measured one, and the stated range covers the measured number.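

In this assay, amino in place of hydroxy on a saturated chain carbon bound to three aromatic carbons gives a 1.2-fold higher number from compound 1 to compound 4 (0.09 log units; within the scatter). Unlike the earlier steps, which were floors that left the hydroxy untouched, this step joins two actual numbers, so its size can be read. At this position, the change from hydroxy to amino moves the read-out no further than the scatter.

On these data alone, how a methoxy or a carboxylic acid would read at this position remains open. So does the effect of amino on the cores of compound 2 and compound 3, where any step would be hard to read because of the assay's ceiling: the limit of > 100000 nM in this assay, at which 2 of the 4 values shown sit.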